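From a Ring Hydrogen to a 4-Methoxybenzyl Group

The compounds below may be only part of what the source reports. "The series", "measured", "known", "first", "only" and "open" are said of these compounds alone.

Compound 1 `COc1ccc(N(C)c2ncnc3[nH]cnc23)cc1` gives > 100000 nM in a functional assay on SH-SY5Y cells (Homo sapiens) for antiproliferative activity, read by MTT assay, with a stated time of 48 h (a higher number here means a weaker inhibitor of growth, a lower number a stronger inhibitor of growth), and this is a limit and not a number. Compound 2 `COc1ccc(N(C)c2nc(Cl)nc3[nH]cnc23)cc1`, with chloro in place of hydrogen on an aromatic carbon, gives > 100000 nM, which is also a limit. Both compounds therefore stand at the limit of > 100000 nM in this assay, at which 2 of the 3 values shown sit. The chloro change is a step that the two limits leave unreadable from compound 1 to compound 2.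

Compound 3 `COc1ccc(N(C)c2nc(Cl)nc3c2ncn3C)cc1`, with methyl in place of hydrogen on an aromatic nitrogen, gives a measured 3400 nM in this assay. That change is an at least 29-fold lower number from compound 2 to compound 3 (1.46 log units; beyond the scatter).

Compound 4 `COc1ccc(Cn2cnc3c(N(C)c4ccc(OC)cc4)ncnc32)cc1` differs from compound 1 by 4-methoxybenzyl in place of hydrogen on an aromatic nitrogen. The nitrogen step is the closest guide, since a hydrogen on an aromatic nitrogen also leaves there, and it was an at least 29-fold lower number from compound 2 to compound 3 (1.46 log units; beyond the scatter). The guide is imperfect, however, as methyl rather than 4-methoxybenzyl enters in that step, and compound 3 carries a chloro that compound 4 lacks. A large step to a lower number in this assay is therefore expected, though with wide uncertainty. The expected change is an at least 10-fold lower number from compound 1 to compound 4 (1.00 log units; beyond the scatter). Compound 4 is estimated at 10000 nM, within an expected range of 1500 nM to 60000 nM.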

Compound 4, concentration for 50% growth inhibition: 27000 nM
Beside the measured number, compound 4's estimate is 2.7-fold (0.43 log units) below it, within the range that was stated.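

In this assay, the step for the ring nitrogen now reads an at least 3.7-fold lower number from compound 1 to compound 4 (0.56 log units; beyond the scatter), which shows that replacing the hydrogen on this aromatic nitrogen lowers the number on the core of compound 1 as well. For the compounds shown here, until now, that lowering had been seen only on a core carrying a chloro and only with methyl entering, whereas here no chloro is present and the entering group is 4-methoxybenzyl, with its six-membered aromatic ring of carbon. Compound 1 gives a limit and not a number, so this step fixes only a minimum size: the limit of > 100000 nM in this assay, at which 2 of the 4 values shown sit.

The compounds shown leave open whether this lowering depends on the aromatic ring of the 4-methoxybenzyl group or on its methoxy, and whether a plain benzyl, a longer alkyl chain or a chain ending in an amine on the same nitrogen would give a lower or a higher number. They also leave open what 4-methoxybenzyl on this nitrogen would give in this assay on the chloro-bearing core of compound 2, where the two changes would stand together.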